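Trading an acetyl for hydrogen on an aromatic nitrogen

A few compounds are considered here, and "the series" means these few. Any claim that something is new, unique, unknown or untested is made for them only; others in the source may bear on it.

Measured compounds:
- compound 1, `COc1ccccc1-c1cc(=O)c2cc(N)ccc2o1`: 74000 nM
- compound 2, `COc1ccccc1-c1oc2ccc(NC(C)=O)cc2c(=O)c1O`: > 125000 nM
- compound 3, `COc1ccccc1-c1oc2ccc(NC(C)=O)cc2c(=O)c1OC`: 108000 nM

All three were tested in an ADME assay on THP-1 cells (Homo sapiens) for cytotoxicity, read by flow cytometry and propidium iodide staining, with a stated time of 72 h; a lower number here means a stronger inhibitor, a higher number a weaker inhibitor. Compound 3 gives the highest of the two plain numbers, and compound 1 sits within the usual scatter of it, so the two cannot be ordered. For compound 2 the result is only a limit of the assay, namely (the limit of > 125000 nM in this assay, at which 1 of the 3 values shown sits), not a number. Among the measured compounds shown here, the one single-point step available is an at least 1.1-fold lower number from compound 2 to compound 3 (0.06 log units; that floor lies within the scatter), which concerns an oxygen on the aromatic ring rather than the nitrogen and gives only a floor that lies within the scatter.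

Compound 4, `COc1ccccc1-c1oc2ccc(N)cc2c(=O)c1OC`, differs from compound 3 in one place: hydrogen in place of acetyl on a nitrogen on an aromatic ring. For the measured compounds named here, no measured step tracks this exact change. Compound 1 also carries a free amino group and its number lies within the scatter of compound 3, though the two differ in more than one place, so this is only a loose hint. Going by the values given here, with no step in hand that moves beyond the scatter, the number for compound 4 in this assay is expected to stay close to that of compound 3, with the step of a 1.3-fold lower number from compound 3 to compound 4 (0.10 log units; within the scatter) estimated as small. Compound 4 is therefore estimated at 85000 nM, within a range of 40000 nM to 170000 nM.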

Compound 4, half-maximal inhibitory concentration: 116000 nM
The estimate for compound 4 lay 1.4-fold (0.14 log units) below the measured number; measured number inside the range.
By their numbers in this assay, from the lowest: compounds 1, 3 and 4 (each within the scatter of the next). At a limit, above all of these: compound 2.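

In this assay, among the compounds shown here, this is the first direct reading of the nitrogen on the aromatic ring: hydrogen in place of acetyl gives a 1.1-fold higher number from compound 3 to compound 4 (0.03 log units; within the scatter), so the acetamido to amino change leaves the number within the scatter. The new compound also gives a second single-place comparison, this time at an aromatic carbon, where methoxy in place of hydrogen gives a 1.6-fold higher number from compound 1 to compound 4 (0.20 log units; within the scatter), again within the scatter. Neither change therefore shifts the cytotoxicity reading by more than repeated measurements would, and compounds 1, 3 and 4 cannot be ordered among themselves.

Going by these compounds, only acetyl and hydrogen have been compared on this nitrogen, so it remains open whether a longer acyl chain such as butanoyl, or a methanesulfonyl group, would move the number beyond the scatter. Also open is where compound 2 really lies, as its result is a limit of the assay and not a number: the limit of > 125000 nM in this assay, at which 1 of the 4 values shown sits.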